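Amide aryl variation on the shared core: toward compound 4

A few compounds are considered here, and "the series" means these few. Any claim that something is new, unique, unknown or untested is made for them only; others in the source may bear on it.

Measured so far in a functional assay on HeLa cells (Homo sapiens) for antiproliferative activity, read by CCK-8 assay, with a stated time of 72 h; on this read-out higher numbers stand for weaker inhibition and lower numbers for stronger inhibition:
Compound 1 `O=C(Nc1cccc(-c2oc3cc(-c4ccc(F)cc4)ccc3c(=O)c2O)c1)c1ccc(F)cc1` gives 5350 nM.
Compound 2 `CCc1ccc(C(=O)Nc2cccc(-c3oc4cc(-c5ccc(F)cc5)ccc4c(=O)c3O)c2)cc1` gives 21000 nM.
Compound 3 `COc1ccc(C(=O)Nc2cccc(-c3oc4cc(-c5ccc(F)cc5)ccc4c(=O)c3O)c2)c(F)c1` gives 16100 nM.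

Compound 1 stands lowest of the three numbers, so it shows the strongest inhibition of the set; the nearest is compound 3 and the furthest compound 2, each separated from it by a step beyond the scatter. Compound 4 `O=C(Nc1cccc(-c2oc3cc(-c4ccc(F)cc4)ccc3c(=O)c2O)c1)c1ccc(Cl)nc1` has not yet been measured. It differs from compound 1 in one place: 6-chloropyridin-3-yl in place of 4-fluorophenyl on a carbonyl carbon. Among the compounds with values here, no measured pair shows this exact change. Within the data shown here, the steps that bear on it are the two changes made to the same part of compound 1: a 3.9-fold higher number from compound 1 to compound 2 (0.59 log units; beyond the scatter) and a 3.0-fold higher number from compound 1 to compound 3 (0.48 log units; beyond the scatter). Both moved the number upward by a modest amount, so every departure from the 4-fluorophenyl group of compound 1 seen so far has cost some potency. A similar or somewhat smaller loss is therefore expected: a 1.5-fold higher number from compound 1 to compound 4 (0.17 log units; within the scatter). For compound 4 the estimated value is 8000 nM, with an expected range from 3000 nM to 22000 nM.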

Compound 4, half-maximal inhibitory concentration: 4080 nM
For compound 4 the middle estimate is 2.0-fold (0.29 log units) above the measured one; measured number inside the range.
By their numbers in this assay, from the lowest: compounds 4 and 1 (each within the scatter of the next); then compounds 3 and 2 (each within the scatter of the next).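

In this assay, the place on the carbonyl carbon accepts a ring with a hetero atom: 6-chloropyridin-3-yl in place of 4-fluorophenyl gives a 1.3-fold lower number from compound 1 to compound 4 (0.12 log units; within the scatter), so a change here need not cost potency, as the earlier changes did. The same group stands clear of the two other aryl groups, with a 3.9-fold lower number from compound 3 to compound 4 (0.60 log units; beyond the scatter) and a 5.1-fold lower number from compound 2 to compound 4 (0.71 log units; beyond the scatter), which places compound 4 with compound 1 at the low end of the series. No measurement at hand accounts for these differences among the aryl groups.

On these data alone, the change swaps the ring nitrogen and the chlorine together, so the share of each stays open; a 4-chlorophenyl or an unsubstituted pyridin-3-yl group would separate them. As far as these compounds go, how an amine or a carboxylic acid on this aryl ring would read also remains open.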